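The source may report more compounds than this note shows. Statements on the series, on what has been measured and on what is new or still open speak of the compounds shown alone.

In a physicochemical assay for solubility, at pH 7.4 (a higher number here means a more soluble compound, a lower number a less soluble compound), two compounds have been measured so far. Compound 1 (`CSc1ccccc1NC(=O)Nc1cc(C)nc2ccccc12`) gives 21000 nM as the higher of the two numbers. Compound 2 (`Cc1cc(NC(=O)Nc2cnc3ccccc3c2)c2ccccc2n1`) gives 400 nM as the lower, and the gap between them lies beyond the usual scatter of repeated measurements. These two compounds differ in more than one place, so no single change can yet be read from them.

Compound 3 (`Cc1cc(NC(=O)Nc2ccccc2[N+](=O)[O-])c2ccccc2n1`) has not been measured. It follows from compound 1 by one change, with nitro in place of methylsulfanyl on an aromatic carbon, ortho to a large group (nitro in place of methylsulfanyl on an aromatic carbon). Going by the values given here, no measured step speaks directly to this change, so the expectation is uncertain. Compound 1 at 21000 nM is the starting point, and compound 2 at 400 nM is the only lower reference. A moderate fall in this assay is expected, probably beyond the scatter. The estimated change a 3.5-fold lower number from compound 1 to compound 3 (0.54 log units; beyond the scatter) is a fall of that moderate size. For compound 3 the expected value is 6000 nM with an estimated range from 1500 nM to 25000 nM in this measurement.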

Compound 3, solubility: 200 nM
Compound 3: middle estimate off by 30-fold (1.48 log units), on the high side; the whole stated range lies above it.
By their numbers in this assay, from the lowest: compounds 3 and 2 (each within the scatter of the next); then compound 1.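

In this assay, going by these compounds alone, replacing methylsulfanyl with nitro, ortho to a large group, gives a 110-fold lower number from compound 1 to compound 3 (2.02 log units; beyond the scatter), a large step and the first single change that can be read. It shows that this one place on the six-membered aromatic ring of carbon only can alone move the reading far beyond the scatter while the rest of the structure stays fixed, even though the exchange is small in count: methylsulfanyl has 2 heavy atoms, nitro has 3, neither brings a ring, and neither carries a net charge. No measured property is available that would account for the size of this step.

The compounds shown leave open whether the step reflects something particular to nitro or the loss of methylsulfanyl, as these are the only two groups seen at this place on the shared core. From the compounds shown here alone, it also remains unknown how an amine, a methoxy group or a carboxylic acid at the same place would read, and whether the same exchange would give a step of similar size elsewhere on that ring.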